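A few compounds are considered here, and "the series" means these few. Any claim that something is new, unique, unknown or untested is made for them only; others in the source may bear on it.

Notes on the series. Compound 1 `Cc1cc(C)c(S(=O)(=O)N2CCC(C(=O)N3CCC(C)CC3)CC2)c(C)c1` is tested in an ADME assay on HCT-116 cells (Homo sapiens) for cytotoxicity, read by CellTiter-Glo, with a stated time of 72 h; on this read-out lower numbers stand for stronger inhibition and higher numbers for weaker inhibition. In this assay compound 1 returns only a limit, > 5000 nM. Compound 2 `CC(=O)Nc1ccc(S(=O)(=O)N2CCC(N3CCC(C)CC3)CC2)c2ccccc12` also returns a limit in this assay, > 10000 nM. Compound 3 `CC1CCN(C2CCN(S(=O)(=O)c3cccc(-c4ccccc4)c3)CC2)CC1` likewise sits at a limit in this assay, > 5000 nM. Every value shown is therefore a limit, the limit of > 5000 nM in this assay, at which 2 of the 3 values shown sit, and (the limit of > 10000 nM in this assay, at which 1 of the 3 values shown sits), so compound 1 cannot be ranked against the others. Compound 4 `Cc1cc(C)c(S(=O)(=O)N2CCC(N3CCCCC3)CC2)c(C)c1` keeps the core of compound 1 and differs in one place: piperidin-1-yl in place of (4-methylpiperidin-1-yl)carbonyl on a saturated ring carbon. Among the measured compounds shown here, no step between measured compounds is available. Compound 4 is expected to move no further than the scatter, a step that the limit leaves unreadable from compound 1 to compound 4. Compound 3, which also carries an amine on that ring carbon, gives > 5000 nM and supports this. For compound 4 the estimate in this assay is 8000 nM, with a range from 3000 nM to 30000 nM, most likely again reported as a limit.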

Compound 4, half-maximal inhibitory concentration: > 5000 nM
Compound 4: no number, only a limit; the forecaster's own chance of this, stated with the estimate: 85%; the middle value is on the limit's open side.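

Compound 1 and compound 4 both return only a limit, so no step between them can be read: the limit of > 5000 nM in this assay, at which 3 of the 4 values shown sit.

The compounds shown leave open where any of them would give a measurable value in this assay.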